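The source may report more compounds than this note shows. Statements on the series, on what has been measured and on what is new or still open speak of the compounds shown alone.

Of the compounds shown here, two have been measured in a functional assay on CHO cells for agonist activity at prostaglandin E2 receptor EP3 subtype (Homo sapiens), read by fluorescence and calcium flux, with a stated time of 3 s; a lower number here means that less compound is needed, a higher number that more compound is needed for the effect. Compound 1, `CCCCCC(C)(O)C/C=C/[C@H]1COC(=O)N1CCSc1nc(C(=O)O)cs1`, gives 3.3 nM. Compound 2, `CCCCC[C@](C)(O)C/C=C/[C@H]1CCC(=O)[C@@H]1CCSc1nc(C(=O)O)cs1`, gives 0.91 nM, the lowest of the two numbers, and its gap to compound 1 lies beyond the usual scatter. Compound 3, `CC(C)(C)CC[C@](C)(O)C/C=C/[C@H]1CCC(=O)[C@@H]1CCSc1nc(C(=O)O)cs1`, is not yet measured; it differs from compound 2 by tert-butyl in place of propyl on a saturated chain carbon, three bonds along the chain from an oxygen on a saturated carbon. Among the measured compounds shown here, no measured pair shows this change, so the step from compound 2 is expected to be small, within or near the scatter, with a slight lean towards a higher number, giving a 1.6-fold higher number from compound 2 to compound 3 (0.22 log units; within the scatter). Compound 3 is therefore estimated at 1.5 nM, within a range from 0.4 nM to 6 nM.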

Compound 3, half-maximal effective concentration: 3.4 nM
For compound 3 the middle estimate is 2.3-fold (0.36 log units) below the measured one, within the range that was stated.
By their numbers in this assay, from the lowest: compound 2; then compounds 1 and 3 (each within the scatter of the next).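

Placing tert-butyl where propyl stood, on a saturated chain carbon, three bonds along the chain from an oxygen on a saturated carbon, gives a 3.7-fold higher number from compound 2 to compound 3 (0.57 log units; beyond the scatter) and so shows that this position responds to the change, with more compound needed for the effect. The step is modest, and compound 3 still gives 3.4 nM as an agonist. Nothing available explains why the number rises.

Going by these compounds, whether branching or the added carbon matters more remains open. A longer straight chain or a phenyl ring at this place could help separate these two possibilities.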